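Extending the propoxy chain with a methylsulfonyl group

This account rests on a few compounds, and the source may have more. Where it says the series, first, only, none or still open, it means among the compounds named here.

Of the compounds shown here, two sharing one core have been tested in a functional assay on CHO cells for agonist activity at Free fatty acid receptor 1 (Homo sapiens), read by FLIPR and calcium flux; on this read-out higher numbers stand for an effect only at larger amounts of compound and lower numbers for an effect already at smaller amounts. Compound 1 `CCOc1cc(C)c(-c2cccc(CNc3ccc(OCC(=O)O)cc3)c2)c(C)c1` gives 197 nM in this assay. Compound 2 `CCCOc1cc(C)c(-c2cccc(CNc3ccc(OCC(=O)O)c(F)c3)c2)c(C)c1` gives 38.7 nM in this assay, the lowest of the two numbers and a gap beyond the usual scatter from compound 1; since the two differ in more than one place, that gap cannot be tied to a single change. Compound 3 `Cc1cc(OCCCS(C)(=O)=O)cc(C)c1-c1cccc(CNc2ccc(OCC(=O)O)c(F)c2)c1` is compound 2 with one alteration: methylsulfonyl in place of hydrogen on a saturated chain carbon, three bonds along the chain from an oxygen on an aromatic ring. Among the measured compounds shown here, no step of this kind between measured compounds is at hand, so the expectation rests on the unchanged remainder of the molecule. The step of a 1.5-fold lower number from compound 2 to compound 3 (0.19 log units; within the scatter) is expected to be small, within or only slightly beyond the scatter, and if anything toward a lower number. Compound 3 is estimated at 25 nM in this assay, with a range from 8 nM to 80 nM.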

Compound 3, half-maximal effective concentration: 59.8 nM
The estimate for compound 3 lay 2.4-fold (0.38 log units) below the measured number; low and high end bracket the measured number.
By their numbers in this assay, from the lowest: compounds 2 and 3 (each within the scatter of the next); then compound 1.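

In this assay, among the compounds shown here, the move from propyl to 3-(methylsulfonyl)propyl gives a 1.5-fold higher number from compound 2 to compound 3 (0.19 log units; within the scatter) and is the first step in this set that can be tied to a single change. It shows that this saturated chain carbon, three bonds along the chain from an oxygen on an aromatic ring, can carry methylsulfonyl, with its 4 heavy atoms and no net charge, while the number remains within the scatter of that of compound 2. No measurement shown here offers an explanation for this tolerance.

As far as these compounds go, whether an amine, a carboxylic acid or a longer chain at the same place would also leave the number within the scatter remains open. So does whether methylsulfonyl would give a similar step on the ethyl end of the chain in compound 1.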